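This account rests on a few compounds, and the source may have more. Where it says the series, first, only, none or still open, it means among the compounds named here.

Measured compounds in an assay on isolated protein for inhibition of protein kinase C zeta type (Homo sapiens), with a stated time of 4 min; on this read-out lower numbers stand for stronger inhibition and higher numbers for weaker inhibition:
compound 1 `Oc1ccc(C2CC(c3ccccc3O)=NN2c2ccc(Cl)cc2)cc1` gives 1500 nM
compound 2 `COc1ccccc1C1=NN(c2ccc(Cl)cc2)C(c2ccc(O)cc2)C1` gives "not determined" (no result reported)
compound 3 `Nc1ccc(C2=NN(c3ccc(Cl)cc3)C(c3ccc(O)cc3)C2)cc1` gives 5400 nM

Of the two numbers available in this assay, compound 1 stands lowest. Its nearest neighbour is compound 3, and the step of a 3.6-fold higher number from compound 1 to compound 3 (0.56 log units; beyond the scatter) lies beyond the scatter. Compound 2 contributes no number and cannot be placed.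

Compound 4 `Oc1ccc(C2CC(c3ccccc3O)=NN2c2ccc(Cl)cc2)cc1O` differs from compound 1 by hydroxy in place of hydrogen on an aromatic carbon. Going by the values given here, none of the measured steps touches this part of the molecule: the single step available, a 3.6-fold higher number from compound 1 to compound 3 (0.56 log units; beyond the scatter), concerns the group on the carbon with a double bond to nitrogen, on the other side of the shared core, and says nothing about a second hydroxy on the 4-hydroxyphenyl. Among the compounds with values here, there is therefore no precedent for this change, and the working assumption is that the numbers stay close to those of compound 1.

The expected step in this assay is no change at the digits printed from compound 1 to compound 4 (within the scatter), that is, none beyond the scatter in either direction. Compound 4 is estimated at 1500 nM in this assay, with a range from 500 nM to 5000 nM reflecting the absence of any comparable step.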

Compound 4, half-maximal inhibitory concentration: < 100 nM
Compound 4: no number, only a limit (the forecaster's own chance of this, stated with the estimate: 5%); middle value at least 15-fold (1.17 log units) away from the limit.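

In this assay, hydroxy in place of hydrogen on the aromatic carbon ortho to a hydroxy group, which turns 4-hydroxyphenyl into 3,4-dihydroxyphenyl, gives an at least 15-fold lower number from compound 1 to compound 4 (1.17 log units; beyond the scatter). Going by these compounds alone, this is the first sign that the 4-hydroxyphenyl side of the shared core responds to substitution, as the only earlier step concerned the group on the carbon with a double bond to nitrogen. Compound 4 gives < 100 nM, which is a limit of the assay and not a number, so the step is a bound and not a measured size: the limit of < 100 nM in this assay, at which 1 of the 4 values shown sits.

The compounds shown hold no amine, methoxy or carboxylic acid at this position, and none carries a 3-hydroxyphenyl group in place of the 4-hydroxyphenyl, so it stays open whether the added hydroxy alone carries the step or needs the hydroxy ortho to it. Also open, from the compounds shown here alone, is whether 3,4-dihydroxyphenyl gives a step of similar size alongside the 4-aminophenyl group of compound 3.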